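The compounds below may be only part of what the source reports. "The series", "measured", "known", "first", "only" and "open" are said of these compounds alone.

Four compounds built around a shared core are described here. Compound 1 `Cc1nc(Nc2ccc(Cl)cc2)sc1C(=O)/C=C/c1ccccc1` carries a 4-chlorophenyl on a nitrogen on an aromatic ring, and in a functional assay on PC-3 cells (Homo sapiens) for cytotoxicity, read by MTT assay (on this read-out higher numbers stand for weaker inhibition and lower numbers for stronger inhibition), compound 1 gives 24600 nM. Compound 3 `Cc1nc(Nc2cccc(Cl)c2)sc1C(=O)/C=C/c1ccccc1` differs from it in one place, (3-chlorophenyl in place of 4-chlorophenyl on a nitrogen on an aromatic ring). In this assay compound 3 returns only a limit of the assay, > 25000 nM. The step of an at least 1.0-fold higher number from compound 1 to compound 3 (0.00 log units; that floor lies within the scatter) is therefore a floor rather than a measured size, and that floor lies within the usual scatter. Compound 2 `COc1cc(/C=C/C(=O)c2sc(Nc3ccc(Cl)cc3)nc2C)cc(OC)c1OC` sits on a different core from compound 1; the difference between the two cores is not broken down here. In this assay compound 2 likewise returns only a limit, > 25000 nM. Among the measured compounds shown here, two of the three values so far rest at the limit of > 25000 nM in this assay, at which 2 of the 3 values shown sit.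

Compound 4 `COc1cc(/C=C/C(=O)c2sc(Nc3cccc(Cl)c3)nc2C)cc(OC)c1OC` has not yet been measured. It differs from compound 2 by 3-chlorophenyl in place of 4-chlorophenyl on a nitrogen on an aromatic ring, the same change, at the same place, as from compound 1 to compound 3. Since compound 2 already stands at a limit and the earlier step of an at least 1.0-fold higher number from compound 1 to compound 3 (0.00 log units; that floor lies within the scatter) moved the number no lower, the step that the limit leaves unreadable from compound 2 to compound 4 is expected to be small and, if anything, toward a higher number. Compound 4 is accordingly expected to give about 40000 nM in this assay, most likely again as a limit, within a range from 20000 nM to 120000 nM.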

Compound 4, half-maximal inhibitory concentration: > 25000 nM
Compound 4 gave a limit, no number (the forecaster's own chance of this, stated with the estimate: 80%); the middle value lies beyond the limit too.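

Among the compounds shown here, compound 2 and compound 4 each return only a limit of this assay, so the step between them cannot be read, and no new step follows from this result: the limit of > 25000 nM in this assay, at which 3 of the 4 values shown sit.

The compounds shown leave open how far compound 2, compound 3 and compound 4 lie past that limit, and whether 3-chlorophenyl in place of 4-chlorophenyl shifts the number at all on either core.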